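This account rests on a few compounds, and the source may have more. Where it says the series, first, only, none or still open, it means among the compounds named here.

Compound 2 `O=c1oc2c(O)cccc2cc1-c1cccs1` carries a thiophen-2-yl group on the shared core. In an assay on CHO cells for displacement of a labelled ligand from adenosine receptor A1 (Homo sapiens) (on this read-out higher numbers stand for weaker inhibition and lower numbers for stronger inhibition), compound 2 gives 3360 nM. Among the numbers shown, compound 2 stands highest of two, and its nearest neighbour is compound 3 `O=c1oc2c(O)c(O)ccc2cc1-c1cccs1`, which in this assay gives 3230 nM; the step of a 1.0-fold lower number from compound 2 to compound 3 (0.02 log units; within the scatter) is within the scatter. Compound 1 `CC(=O)Oc1cccc2cc(-c3ccsc3)c(=O)oc12` is reported only as a limit: in this assay compound 1 gives > 100000 nM (the limit of > 100000 nM in this assay, at which 1 of the 3 values shown sits).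

Compound 4 `O=c1oc2c(O)cccc2cc1-c1ccsc1` has not yet been measured. It differs from compound 2 in one place: thiophen-3-yl in place of thiophen-2-yl on an aromatic carbon. For the measured compounds named here, none of the measured steps changes the point at which the thiophene ring is attached; the single measured step, from compound 2 to compound 3, alters a different position and stays within the scatter, so it offers no guide to the size of this change. Compound 1 also carries thiophen-3-yl, but it differs from compound 4 in a second place as well, and its value is a limit rather than a number, so it cannot fix the size either.

On this basis the expected step of a 1.5-fold higher number from compound 2 to compound 4 (0.17 log units; within the scatter) is a modest one, most likely toward a higher number in this assay. Compound 4 is therefore estimated at 5000 nM, with a range from 1500 nM to 20000 nM.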

Compound 4, inhibition constant: 5920 nM
Compound 4: the middle estimate sits 1.2-fold (0.07 log units) below what was measured; low and high end bracket the measured number.
By their numbers in this assay, from the lowest: compounds 3, 2 and 4 (each within the scatter of the next). At a limit, above all of these: compound 1.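

In this assay, thiophen-3-yl in place of thiophen-2-yl gives a 1.8-fold higher number from compound 2 to compound 4 (0.25 log units; within the scatter), so this first measured change of the thiophene's attachment point does not separate the two ring forms on the shared core. Compound 4 also gives the first clean comparison for the acetyl group on the oxygen: hydrogen in place of acetyl gives an at least 16-fold lower number from compound 1 to compound 4 (1.22 log units; beyond the scatter), a large step and the only one shown that lies beyond the scatter, which marks this oxygen substituent as the change that counts here, not the thiophene's attachment point. The true size of that step stays unknown, and it can only be stated as a minimum, since compound 1 is reported as a limit and not as a number: the limit of > 100000 nM in this assay, at which 1 of the 4 values shown sits.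

The compounds shown leave open how a methyl group or a longer chain on that oxygen would compare with hydrogen and acetyl, and so whether acetyl is a special case. They also leave open whether a phenyl ring or a furan ring in place of the thiophene would fall within the scatter of compound 2 and compound 4 or move clearly away from them.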